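The source may hold more compounds than are shown below. What is called first, only, known or untested is meant among the compounds shown, and "the series" means these compounds.

Among the compounds with values here, in an assay on cells for inhibition of histone deacetylase 11 (Homo sapiens), read by fluorescence, with stated times of 3 h and 30 min, tested at 2 uM, in the presence of a further agent that is not named here (on this read-out lower numbers stand for less inhibition and higher numbers for more inhibition at the one concentration tested (going by the name of the read-out)), compound 2 `Nc1ccccc1NC(=O)/C=C/c1cn([C@H]2C[C@@H](CO)N(CCCc3ccccc3)C2)nn1` gives 19%, the only plain number among the measured pair. Compound 1 `Nc1ccccc1NC(=O)/C=C/c1cn([C@H]2C[C@H](C(=O)O)N(CCCc3ccccc3)C2)nn1` returns only a limit of the assay, < 10%; that limit is where one of the two measured values sits (the limit of < 10% in this assay, at which 1 of the 2 values shown sits). Compound 3 `Nc1ccccc1NC(=O)/C=C/c1cn([C@H]2C[C@H](CO)N(CCCc3ccccc3)C2)nn1` has not yet been measured; it differs from compound 2 only in drawn configuration: the two compounds have the same atoms and bonds and differ only in configuration as drawn: 1 of 3 stereo elements differ; a stereocentre at a saturated ring carbon is drawn S in compound 2 and R in compound 3. Within the data shown here, no measured step of this kind exists here. The change from compound 2 to compound 3 in this assay is expected to stay within the usual scatter, with no clear direction. Compound 3 is estimated to give 15%, likely between 5% and 28%. That estimate means an expected step of a number 4 percentage points lower from compound 2 to compound 3 (within the scatter).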

Compound 3, a percentage reported as inhibition, at one concentration (the size of the read-out at that concentration, not a potency): 16%
The estimate for compound 3 lay 1 percentage points below the measured number; the measured number falls inside the stated range.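

In this assay, changing the drawn configuration at this saturated ring carbon gives a number 3 percentage points lower from compound 2 to compound 3 (within the scatter), so this read-out separates the two forms no further at the one concentration tested. Hydroxymethyl in place of carboxy on the same ring carbon gives a number at least 6 percentage points higher from compound 1 to compound 3 (that floor lies within the scatter). Compound 1 gives < 10%, a limit of the assay and not a number, so this step is only a floor.

On these data alone, how an aminomethyl group on this ring carbon would read remains open. So does whether drawn configuration matters when carboxy sits there.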